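Benzimidazolyl amide in place of hydroxypropyl amide: Vero cytotoxicity

The source may report more compounds than this note shows. Statements on the series, on what has been measured and on what is new or still open speak of the compounds shown alone.

Measured so far:
compound 1 `Cc1csc(NC(=O)c2cccc3[nH]c(-c4ccncc4)nc23)n1` gives 111 uM
compound 2 `COc1ccc(-c2nc3c(C(=O)NCCCO)cccc3[nH]2)cc1OC` gives 46 uM
compound 3 `COc1ccc(-c2nc3c(C(=O)Nc4ccccc4F)cccc3[nH]2)c(OC)c1OC` gives 37.8 uM

These three compounds were tested in an ADME assay on Vero cells (Chlorocebus sabaeus) for cytotoxicity; on this read-out higher numbers stand for lower toxicity in this test and lower numbers for higher toxicity in this test. Of the three numbers, compound 2 has the second highest; its nearest neighbour is compound 3, whose number is lower by an amount within the scatter, while compound 1 lies further away with a higher number, beyond the scatter.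

Compound 4 `COc1ccc(-c2nc3c(C(=O)Nc4nc5ccccc5[nH]4)cccc3[nH]2)cc1OC` has not yet been measured in this assay. It differs from compound 2 in one place: 1H-benzimidazol-2-yl in place of 3-hydroxypropyl on an amide-type nitrogen. The shared core is unchanged.

Going by the values given here, no step between two measured compounds isolates this change, so the expectation rests on what the three values show. Compound 3, which also carries an aromatic group on the amide nitrogen, gives 37.8 uM, within the scatter of compound 2. Compound 4 is therefore expected to sit close to compound 2, with at most a small step toward higher toxicity in this assay, and the step from compound 2 to compound 4 is estimated as a 1.4-fold lower number from compound 2 to compound 4 (0.16 log units; within the scatter). For compound 4 the estimated value is 32 uM, with a range from 12 uM to 85 uM.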

Compound 4, half-maximal toxic concentration: 51.8 uM
Estimate against measurement, compound 4: 1.6-fold (0.21 log units) below; low and high end bracket the measured number.
By their numbers in this assay, from the lowest: compounds 3, 2 and 4 (each within the scatter of the next); then compound 1.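

In this assay, going by these compounds alone, this is the first step that isolates a change on the amide-type nitrogen: 1H-benzimidazol-2-yl in place of 3-hydroxypropyl gives a 1.1-fold higher number from compound 2 to compound 4 (0.05 log units; within the scatter). On this shared core, then, an open chain without a ring and a group with one five-membered and one six-membered aromatic ring cannot be told apart in this read-out. Nothing available explains why the read-out stays level across this change.

The compounds shown leave open whether the number would also hold with other groups on this nitrogen, such as a propyl chain ending in an amine or a carboxylic acid. As far as these compounds go, whether the same change behaves alike on other cores also stays open, as compound 1 and compound 3 each differ from compound 4 in more than one place.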